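Swapping Benzyl for Phenyl on a Cytotoxicity Readout

A few compounds are considered here, and "the series" means these few. Any claim that something is new, unique, unknown or untested is made for them only; others in the source may bear on it.

Three compounds were tested in an ADME assay on Huh-7 cells (Homo sapiens) for cytotoxicity, read by MTT assay, with a stated time of 3 days; a lower number here means that less compound is tolerated, a higher number that more compound is tolerated. Compound 1 `O=C(/C=C/c1ccc(OCCc2ccccc2)cc1)NO` gives 16000 nM in this assay. Compound 2 `O=C(/C=C/c1ccccc1OCc1ccccc1)NO` gives 31000 nM, and compound 3 `O=C(/C=C/c1ccccc1OCCc1ccccc1)NO` gives 83000 nM. Compound 2 and compound 3 differ in one place: phenyl in place of benzyl on a saturated chain carbon bound to an oxygen on an aromatic ring. That change produced a 2.7-fold lower number from compound 3 to compound 2 (0.43 log units; beyond the scatter). Compound 1 and compound 3 are built from the same atoms joined differently; the difference between the two cores is not broken down here.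

The unmeasured compound 4 `O=C(/C=C/c1ccc(OCc2ccccc2)cc1)NO` relates to compound 1 by the same change: phenyl in place of benzyl on a saturated chain carbon bound to an oxygen on an aromatic ring. Among the measured compounds shown here, the step from compound 1 to compound 4 is expected to be a 2.3-fold lower number from compound 1 to compound 4 (0.36 log units; beyond the scatter), resting on the single earlier example, a 2.7-fold lower number from compound 3 to compound 2 (0.43 log units; beyond the scatter). Compound 4 is therefore estimated at 7000 nM in this assay, with a likely range from 3000 nM to 17000 nM.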

Compound 4, half-maximal cytotoxic concentration: 9900 nM
For compound 4 the middle estimate is 1.4-fold (0.15 log units) below the measured one, within the range that was stated.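

In this assay, the change on the core of compound 1 gives a 1.6-fold lower number from compound 1 to compound 4 (0.21 log units; within the scatter), so this step alone is too small to count as a real shift. Set beside the earlier step, the two show no difference that can be told apart from measurement noise: the same change on two cores in this assay, a 2.7-fold lower number (0.43 log units; beyond the scatter) from compound 3 to compound 2 and a 1.6-fold lower number (0.21 log units; within the scatter) from compound 1 to compound 4, 1.7-fold (0.22 log units) apart, within the scatter of two such steps. The change therefore behaves alike on these two cores, as far as they can show, but two examples cannot establish a rule for other cores or explain why the number moves.

The compounds shown leave open what a longer chain in place of benzyl would do to the number. They also leave open the effect of an amine or a carboxylic acid on the phenyl group.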